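This account rests on a few compounds, and the source may have more. Where it says the series, first, only, none or still open, it means among the compounds named here.

Compound 1 `CCOC(=O)CCCCCOc1cccc(CN(C(=O)c2ccc(-c3ccc4ccccc4c3)cc2)C(C)C)c1` gives > 26000 nM in an ADME assay on HEK293 cells (Homo sapiens) for cytotoxicity, read by CellTiter-Glo and resazurin assay, with a stated time of 72 h; a lower number here means that less compound is needed, a higher number that more compound is needed for the effect.
Compound 2 `CCOC(=O)CCCCCOc1cccc(CN(C(=O)c2ccc(-c3ccc(C(C)=O)s3)cc2)C(C)C)c1` gives > 26000 nM in this assay.
Compound 3 `CCOC(=O)CCCCCOc1cccc(CN(C(=O)c2ccc(-c3ccc4[nH]ccc4c3)cc2)C(C)C)c1` gives > 26000 nM in this assay.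

Each of these three values is a limit of the assay, not a number. Compound 3 therefore stands at the same limit as the other two, (the limit of > 26000 nM in this assay, at which 3 of the 3 values shown sit). The next compound, compound 4 `CCOC(=O)CCCCCOc1cccc(CN(C(=O)c2ccc(-c3cc(OC)cc(OC)c3)cc2)C(C)C)c1`, differs from compound 3 by 3,5-dimethoxyphenyl in place of 1H-indol-5-yl on an aromatic carbon. The three measured steps all exchange the same group and all remain unreadable: a step that the two limits leave unreadable from compound 1 to compound 2, a step that the two limits leave unreadable from compound 1 to compound 3 and a step that the two limits leave unreadable from compound 2 to compound 3. No change beyond the scatter can be read from them, so for compound 4 the expected step is a step that the limit leaves unreadable from compound 3 to compound 4, most likely again a limit. The estimate for compound 4 in this assay is 30000 nM, between 15000 nM and 60000 nM.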

Compound 4, half-maximal effective concentration: > 26000 nM
Compound 4 was reported as a limit (the forecaster's own chance of this, stated with the estimate: 80%); the middle value is on the limit's open side.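

Compound 4 also gives only a limit, so no step between compound 1, compound 2, compound 3 and compound 4 can be read: the limit of > 26000 nM in this assay, at which 4 of the 4 values shown sit.

On these data alone, whether these four compounds differ at all in this assay stays open, as none of them has an actual number.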